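A Fluorine Added to the Benzyl Ether

The source may report more compounds than this note shows. Statements on the series, on what has been measured and on what is new or still open speak of the compounds shown alone.

Measured compounds:
Compound 1 `Cc1ccc(NC(=S)NC(=O)c2ccc(OCc3ccc(Cl)c(Cl)c3)cc2)cc1-c1nc2ccccc2[nH]1`: in a functional assay on SW-620 cells (Homo sapiens) for inhibition, read by MTT assay, with a stated time of 48 h (a lower number here means a stronger inhibitor, a higher number a weaker inhibitor), compound 1 gives 30700 nM.
Compound 2 `O=C(NC(=S)Nc1ccc(Cl)c(-c2nc3ccccc3[nH]2)c1)c1ccc(OCc2ccc(Cl)c(Cl)c2)cc1`: in this assay compound 2 gives 24900 nM.
Compound 3 `Cc1ccc(NC(=O)NC(=O)c2ccc(OCc3ccccc3)cc2)cc1-c1nc2ccccc2[nH]1`: in this assay compound 3 gives 30100 nM.

The three numbers sit close together. Compound 3 is within the usual scatter of both compound 1 and compound 2, so nothing separates it from either of them. Within the data shown here, the only pair that differs in a single place is compound 1 and compound 2, and that change gave a 1.2-fold lower number from compound 1 to compound 2 (0.09 log units; within the scatter).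

Compound 4 `Cc1ccc(NC(=O)NC(=O)c2ccc(OCc3ccccc3F)cc2)cc1-c1nc2ccccc2[nH]1` differs from compound 3 by fluoro in place of hydrogen on an aromatic carbon. Among the measured compounds shown here, this change sits on the benzyl ether end of the molecule, a part left untouched in the one measured step, which swapped a methyl for a chloro on a different ring. For the measured compounds named here, no measured step therefore bears directly on it. Going by the values given here, what is known is only that the one single-point change seen so far, from compound 1 to compound 2, stayed within the scatter, and that all three numbers cluster in the same region of this assay.

On that basis the step from compound 3 to compound 4 is expected to be a 1.1-fold lower number from compound 3 to compound 4 (0.03 log units; within the scatter), not beyond the scatter in either direction. Compound 4 is estimated at 28000 nM in this assay, with a range from 12000 nM to 65000 nM.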

Compound 4, half-maximal inhibitory concentration: 4110 nM
Beside the measured number, compound 4's estimate is 6.8-fold (0.83 log units) above it, and the stated range ends above it.
By their numbers in this assay, from the lowest: compound 4; then compounds 2, 3 and 1 (each within the scatter of the next).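

In this assay, a single fluoro on the benzyl ether end of the molecule gives the first step among these compounds to go beyond the scatter, with a 7.3-fold lower number from compound 3 to compound 4 (0.86 log units; beyond the scatter) for the change from benzyl to 2-fluorobenzyl. Among these compounds, the only earlier step, chloro in place of methyl on a different ring, stayed within the scatter, so the earlier compounds gave no sign that the number could respond to so small an edit. This aromatic carbon, ortho to a large group, is therefore a place where adding one heavy atom changes the reading in this cell assay, although nothing available here explains how.

Fluoro is the only group shown at this carbon, so it remains open whether chloro, methoxy or an amine in the same place would lower the number as well, or whether fluoro on another carbon of that ring would do the same. Also open, on these data alone, is whether the same fluoro would produce a similar step when added to compound 1 or compound 2, which differ from compound 3 elsewhere in the molecule.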